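Aryl Swap on a Piperazine Nitrogen: Chloro, Methoxy, Nitro

This account rests on a few compounds, and the source may have more. Where it says the series, first, only, none or still open, it means among the compounds named here.

Compound 2 `COc1ccccc1N1CCN(CCCCOc2ccc3c(c2)CCC3)CC1` gives 33% in a functional assay on the whole organism for inhibition, with Mus musculus as the target, at a dose of 25 mg/kg by the oral route; on this read-out higher numbers stand for more inhibition at the one dose given (going by the name of the read-out) and lower numbers for less inhibition; compound 1 `Clc1ccc(N2CCN(CCCCOc3ccc4c(c3)CCC4)CC2)cc1` gives 31%, and the two stand within the scatter of each other, with a number 2 percentage points higher from compound 1 to compound 2 (within the scatter). Compound 3 `O=[N+]([O-])c1ccc(N2CCN(CCCCOc3ccc4c(c3)CCC4)CC2)cc1` differs from compound 2 by 4-nitrophenyl in place of 2-methoxyphenyl on an amine nitrogen in a ring. Among the compounds with values here, the only measured step exchanges one aryl group for another on the same ring nitrogen and stays within the scatter, so a step of similar size, in either direction or none beyond the scatter, is expected here. Compound 3 is therefore estimated at 30%, between 10% and 52%, a step of a number 3 percentage points lower from compound 2 to compound 3 (within the scatter).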

Compound 3, a percentage reported as inhibition, in the whole organism at one dose (the size of the read-out at that dose, not a potency): 0%
Compound 3: middle estimate off by 30 percentage points, on the high side; measured number below the stated range.
By their numbers in this assay, from the lowest: compound 3; then compounds 1 and 2 (each within the scatter of the next).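

The aryl group on the ring nitrogen turns out not to be freely exchangeable in this assay: 4-nitrophenyl in place of 2-methoxyphenyl gives a number 33 percentage points lower from compound 2 to compound 3 (beyond the scatter), whereas the earlier exchange gave only a number 2 percentage points higher from compound 1 to compound 2 (within the scatter). Nitro in place of chloro on an aromatic carbon gives a number 31 percentage points lower from compound 1 to compound 3 (beyond the scatter), so the drop appears against both earlier aryl groups. Nothing available explains this drop. From the compounds shown here alone, whether it is specific to nitro, or would also come with a nitrile or an amino group at that place on the phenyl ring, stays open.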